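Heptyl to trifluoromethyl on the aryl urea series

The compounds below may be only part of what the source reports. "The series", "measured", "known", "first", "only" and "open" are said of these compounds alone.

Measured so far:
compound 1, `C[C@H](NC(=O)Nc1ccc(C(C)(C)C)cc1)c1ccccc1`, 64%
compound 2, `CCCCc1ccc(NC(=O)N[C@@H](C)c2ccccc2)cc1`, 60%
compound 3, `CCCCCCCc1ccc(NC(=O)N[C@@H](C)c2ccccc2)cc1`, 99%

In an ADME assay on the whole organism with Oryza sativa as the target, tested at 10 uM (a lower number here means a stronger effect, a higher number a weaker effect of the compound at the concentration tested), compound 3 stands highest of the three. The step of a number 35 percentage points higher from compound 1 to compound 3 (beyond the scatter) and the step of a number 39 percentage points higher from compound 2 to compound 3 (beyond the scatter) are both large and beyond the scatter, whereas a number 4 percentage points lower from compound 1 to compound 2 (within the scatter) stays within it, so the two shorter groups on the aromatic carbon sit together and heptyl alone stands apart.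

Compound 4, `C[C@H](NC(=O)Nc1ccc(C(F)(F)F)cc1)c1ccccc1`, has not yet been measured. trifluoromethyl in place of heptyl on an aromatic carbon

Going by the values given here, the steps that bear on this change are the two that lead into heptyl, a number 35 percentage points higher from compound 1 to compound 3 (beyond the scatter) and a number 39 percentage points higher from compound 2 to compound 3 (beyond the scatter). Read in reverse, leaving heptyl for either butyl or tert-butyl lowers the number by a large amount. Trifluoromethyl has not been measured in this set, so there is no step that tells how it compares with butyl or tert-butyl; the only guide is that every group other than heptyl gave a number in the region of compound 1 and compound 2.

The step of a number 37 percentage points lower from compound 3 to compound 4 (beyond the scatter) is therefore expected to be large and downward, beyond the scatter. For compound 4 the estimate in this assay is 62%, with a range from 40% to 85%.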

Compound 4, a percentage reported as activity, at one concentration (the size of the read-out at that concentration, not a potency): 94%
The estimate for compound 4 lay 32 percentage points below the measured number; measured number outside the range, above it.
By their numbers in this assay, from the lowest: compounds 2 and 1 (each within the scatter of the next); then compounds 4 and 3 (each within the scatter of the next).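

In this assay, the step of a number 5 percentage points lower from compound 3 to compound 4 (within the scatter) stays within the scatter, so heptyl no longer stands alone at this aromatic carbon: trifluoromethyl, with 4 heavy atoms against 7, sits with it. The steps of a number 34 percentage points higher from compound 2 to compound 4 (beyond the scatter) and a number 30 percentage points higher from compound 1 to compound 4 (beyond the scatter) both lie beyond the scatter, which divides the four compounds into two pairs, butyl and tert-butyl on one side and heptyl and trifluoromethyl on the other, so the number does not follow the length of the group at this position across these compounds. No supporting data bear on what separates the two pairs.

Open, on these data alone, is where a chlorine, a methoxy group or a pentyl chain would fall, and whether any such group would join one of the two pairs or land between them. Also open, as far as these compounds go, is whether the same split between the pairs would hold with a carboxylic acid or an amine at this position, or with a change elsewhere on the shared core.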